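Swapping the aryl group on the ring nitrogen

The source may hold more compounds than are shown below. What is called first, only, known or untested is meant among the compounds shown, and "the series" means these compounds.

Measured so far in a functional assay on PC-3 cells (Homo sapiens) for cytotoxicity, read by MTT assay, with a stated time of 72 h; a lower number here means a stronger inhibitor, a higher number a weaker inhibitor:
compound 1 `Cc1cc(=O)n(-c2cccc(F)c2)nc1C(=O)Nc1ccc(Oc2ncnc3[nH]ccc23)cc1`: 14600 nM
compound 2 `Cc1ccc(-n2nc(C(=O)Nc3ccc(Oc4ncnc5[nH]ccc45)cc3)c(C)cc2=O)cc1`: 9610 nM
compound 3 `Cc1cc(=O)n(-c2ccccc2OC(F)(F)F)nc1C(=O)Nc1ccc(Oc2ncnc3[nH]ccc23)cc1`: 22500 nM

Among these three, compound 3 gives the highest number; from compound 1 the step is a 1.5-fold higher number from compound 1 to compound 3 (0.19 log units; within the scatter), and from compound 2 it is a 2.3-fold higher number from compound 2 to compound 3 (0.37 log units; beyond the scatter). Compound 4 `Cc1cc(=O)n(-c2ccc(Br)cc2F)nc1C(=O)Nc1ccc(Oc2ncnc3[nH]ccc23)cc1` differs from compound 3 in one place: 4-bromo-2-fluorophenyl in place of 2-(trifluoromethoxy)phenyl on an aromatic nitrogen. The measured steps that bear on this are all exchanges of the aryl group on that ring nitrogen: a 1.5-fold lower number from compound 1 to compound 2 (0.18 log units; within the scatter), a 1.5-fold higher number from compound 1 to compound 3 (0.19 log units; within the scatter) and a 2.3-fold higher number from compound 2 to compound 3 (0.37 log units; beyond the scatter), none of them larger than modest. A similarly small step is therefore expected for compound 4, a 1.5-fold lower number from compound 3 to compound 4 (0.18 log units; within the scatter). Since compound 3 gives 22500 nM, the highest of the three, any shift seems more likely toward a lower number than a higher one. Compound 4 is estimated at 15000 nM, with a range from 6000 nM to 40000 nM.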

Compound 4, half-maximal inhibitory concentration: 2730 nM
Estimate against measurement, compound 4: 5.5-fold (0.74 log units) above; measured number outside the range, below it.
By their numbers in this assay, from the lowest: compound 4; then compounds 2, 1 and 3 (each within the scatter of the next, the first and the last beyond it).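

The ring-nitrogen aryl position is more sensitive than the earlier exchanges suggested: in this assay the 4-bromo-2-fluorophenyl group gives an 8.2-fold lower number from compound 3 to compound 4 (0.92 log units; beyond the scatter) and a 3.5-fold lower number from compound 2 to compound 4 (0.55 log units; beyond the scatter) and also a 5.3-fold lower number from compound 1 to compound 4 (0.73 log units; beyond the scatter) with each step beyond the scatter. Compound 4 therefore has the lowest number of the four, clear of all the others. Nothing measured here says why this aryl group gives a lower number.

As far as these compounds go, whether the bromine or the fluorine matters more stays open, as compound 4 carries both. Also open, from the compounds shown here alone, is what an amine or a carboxylic acid in place of the bromine would give.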